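Pyridin-4-yl on the aromatic nitrogen: a first estimate

This account rests on a few compounds, and the source may have more. Where it says the series, first, only, none or still open, it means among the compounds named here.

In a functional assay on HepG2 cells (Homo sapiens) for inhibition, read by sulforhodamine B assay, with a stated time of 72 h (on this read-out lower numbers stand for stronger inhibition and higher numbers for weaker inhibition), compound 1 `C[C@H](Nc1ncnc2[nH]cnc12)c1nn(-c2ccc(C#N)cc2)c2cc(F)ccc12` gives 15100 nM and compound 2 `C[C@H](Nc1ncnc2[nH]cnc12)c1nn(-c2cccc(S(C)(=O)=O)c2)c2cc(F)ccc12` gives 14800 nM. Among the measured compounds shown here, compound 2 therefore stands level with compound 1, the only other measured compound, and the two values lie within the scatter of each other.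

Compound 3 `C[C@H](Nc1ncnc2[nH]cnc12)c1nn(-c2ccncc2)c2cc(F)ccc12` carries pyridin-4-yl in place of 3-(methylsulfonyl)phenyl on an aromatic nitrogen.

For the measured compounds named here, one measured step bears on this change, also on an aromatic nitrogen: a 1.0-fold lower number from compound 1 to compound 2 (0.01 log units; within the scatter). That step, between compound 1 and compound 2, exchanges one substituted phenyl for another and stays within the scatter. Going by the values given here, no measured compound has a hetero atom in the ring at this place, so the support is indirect, and no direction can be argued.

The expected outcome is a 1.1-fold lower number from compound 2 to compound 3 (0.02 log units; within the scatter), with no shift beyond the scatter anticipated. For compound 3 the estimated value is 14000 nM, with an expected range of 6000 nM to 32000 nM.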

Compound 3, half-maximal inhibitory concentration: 23100 nM
The estimate for compound 3 lay 1.7-fold (0.22 log units) below the measured number, and the stated range covers the measured number.
By their numbers in this assay, from the lowest: compounds 2, 1 and 3 (each within the scatter of the next).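

In this assay, pyridin-4-yl brings the first hetero atom into the ring on the aromatic nitrogen, and it has fewer heavy atoms than 3-(methylsulfonyl)phenyl, yet both new steps stay within the scatter (a 1.6-fold higher number from compound 2 to compound 3 (0.19 log units; within the scatter); a 1.5-fold higher number from compound 1 to compound 3 (0.18 log units; within the scatter)). Across these three compounds, neither a ring nitrogen in place of ring carbon nor the loss of the methylsulfonyl group separates one compound from the others, so this place has so far shown no step beyond the scatter. No supporting data are available to account for these small differences.

As far as these compounds go, all three groups at this place are six-membered aromatic rings, so the effect of a saturated amine such as piperidin-4-yl or of a plain alkyl chain remains open. A phenyl ring bearing a carboxylic acid is likewise untested among the compounds shown.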